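The source may report more compounds than this note shows. Statements on the series, on what has been measured and on what is new or still open speak of the compounds shown alone.

Measured in an ADME assay on MT4 cells (Homo sapiens) for cytotoxicity, read by MTT assay, with a stated time of 4 days; a higher number here means that more compound is tolerated, a lower number that less compound is tolerated:
- Compound 1 `CCCNc1nc(C(C)c2c(F)cccc2F)c(C)c(=O)[nH]1`: 35000 nM
- Compound 2 `CCCN(C)c1nc(C(C)c2c(F)cccc2F)c(C)c(=O)[nH]1`: > 78000 nM, a limit
- Compound 3 `Cc1c(C(C)c2c(F)cccc2F)nc(N2CCCC(C)C2)[nH]c1=O`: not yet measured

Compound 2 stands at the limit of > 78000 nM in this assay, at which 1 of the 2 values shown sits, so its true value is not known, and it is only known to be well tolerated in this assay. The change 3-methylpiperidin-1-yl in place of methyl(propyl)amino on an aromatic carbon places 3-methylpiperidin-1-yl where methyl(propyl)amino stood on an aromatic carbon. Among the measured compounds shown here, one measured step bears on this: an at least 2.2-fold higher number from compound 1 to compound 2 (0.34 log units; beyond the scatter), where a methyl replaced a hydrogen on the same amino nitrogen. That step is only a lower bound and concerns a smaller change, so it is a weak guide. Compound 3, like compound 2, has no hydrogen on that nitrogen, so tolerance is expected to stay high. The expected move is an at least 1.3-fold lower number from compound 2 to compound 3 (0.11 log units; that floor lies within the scatter), which is not clearly beyond the scatter. Compound 3 is estimated at 60000 nM, with an expected range of 22000 nM to 110000 nM.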

Compound 3, half-maximal cytotoxic concentration: > 72000 nM
Compound 3 ended at the assay's limit; the forecaster's own chance of this, stated with the estimate: 50%; at least 1.2-fold (0.07 log units) between middle value and limit.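

In this assay, compound 3 gives > 72000 nM, which is a limit of the assay and not a number. This shows that the aromatic carbon between two ring nitrogen atoms can carry a six-membered non-aromatic ring, 3-methylpiperidin-1-yl, as well as the open chain methyl(propyl)amino, and that measured against propylamino the change gives an at least 2.0-fold higher number from compound 1 to compound 3 (0.31 log units; beyond the scatter). The step from compound 2 to compound 3 cannot be read, as both values are limits, so these two groups cannot be ranked against each other.

From the compounds shown here alone, how far the true values of compound 2 and compound 3 lie past their limits remains open. Also open, going by these compounds, is whether the tolerance would hold for a morpholine ring, a smaller pyrrolidine ring, or a piperidine carrying a carboxylic acid at this carbon.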